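The compounds below may be only part of what the source reports. "The series", "measured", "known", "first", "only" and "open" are said of these compounds alone.

In an ADME assay on A549 cells (Homo sapiens) for cytotoxicity, read by resazurin assay, with a stated time of 48 h (on this read-out higher numbers stand for lower toxicity in this test and lower numbers for higher toxicity in this test), compound 1 `CCNc1ccc(NC(=O)c2cc(Cl)ccc2O)c(Cl)c1` gives 30200 nM, compound 2 `CCCCCCC(C)Nc1ccc(NC(=O)c2cc(Cl)ccc2O)c(Cl)c1` gives 23500 nM and compound 3 `O=C(Nc1ccc(NCc2cccc(C(F)(F)F)c2)cc1Cl)c1cc(Cl)ccc1O` gives 13300 nM, so the last two lie within the scatter of each other. Compound 4 `O=C(Nc1ccc(NCc2cc(F)cc(Cl)c2)cc1Cl)c1cc(Cl)ccc1O` carries one change: 3-chloro-5-fluorophenyl in place of 3-(trifluoromethyl)phenyl on a saturated chain carbon bound to a nitrogen on an aromatic ring. Here, 3-chloro-5-fluorophenyl replaces 3-(trifluoromethyl)phenyl on a saturated chain carbon bound to a nitrogen on an aromatic ring. Two measured steps altered groups on such a carbon: a 1.3-fold lower number from compound 1 to compound 2 (0.11 log units; within the scatter), and a 2.3-fold lower number from compound 1 to compound 3 (0.36 log units; beyond the scatter). Even the larger step was modest, and neither exchanged one substituted phenyl for another. No step beyond the scatter is therefore expected in this assay, and no direction is favoured. The estimated step is a 1.0-fold lower number from compound 3 to compound 4 (0.01 log units; within the scatter). For compound 4 the expected value is 13000 nM, with an estimated range from 7000 nM to 24000 nM.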

Compound 4, half-maximal cytotoxic concentration: 11100 nM
Compound 4: the middle estimate sits 1.2-fold (0.07 log units) above what was measured; the measured number falls inside the stated range.
By their numbers in this assay, from the lowest: compounds 4, 3, 2 and 1 (each within the scatter of the next, the first and the last beyond it).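

In this assay, within the data shown here, exchanging one substituted phenyl for another on this carbon gives a 1.2-fold lower number from compound 3 to compound 4 (0.08 log units; within the scatter) and so leaves the number effectively unchanged, which the earlier steps, none of them between two substituted phenyls, could not show. The new group also gives a 2.1-fold lower number from compound 2 to compound 4 (0.33 log units; beyond the scatter) with 3-chloro-5-fluorobenzyl in place of 1-methylheptyl, and a 2.7-fold lower number from compound 1 to compound 4 (0.43 log units; beyond the scatter) with 3-chloro-5-fluorophenyl in place of methyl, both modest steps. On these data alone, whether a phenyl bearing an amine or a carboxylic acid would behave alike remains open. Nothing available accounts for these steps.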